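A few compounds are considered here, and "the series" means these few. Any claim that something is new, unique, unknown or untested is made for them only; others in the source may bear on it.

Compound 2 `CC1CCN(c2nc(C(F)(F)F)ccc2CNC(=O)C(c2ccc(NS(C)(=O)=O)c(F)c2)C2CCCC2)CC1` stands second highest of the three numbers in an assay on CHO cells for antagonist activity at transient receptor potential cation channel subfamily V member 1 (Homo sapiens), read by FLIPR; on this read-out higher numbers stand for weaker inhibition and lower numbers for stronger inhibition; its nearest neighbour is compound 3 `CS(=O)(=O)Nc1ccc(C(C(=O)NCc2ccc(C(F)(F)F)nc2SC2CCCCC2)C2CCCC2)cc1F`, and a 1.2-fold higher number from compound 2 to compound 3 (0.06 log units; within the scatter), while the furthest is compound 1 `CCC(C(=O)NCc1ccc(C(F)(F)F)nc1N1CCC(C)CC1)c1ccc(NS(C)(=O)=O)c(F)c1`. In this assay compound 1 gives 1.6 nM, compound 2 gives 88.7 nM and compound 3 gives 103 nM. Compound 4 `CC1CCN(c2nc(C(F)(F)F)ccc2CNC(=O)C(c2ccc(NS(C)(=O)=O)c(F)c2)C2CCCCC2)CC1` differs from compound 2 by cyclohexyl in place of cyclopentyl on a saturated chain carbon bound to an aromatic carbon and a carbonyl carbon. Among the compounds with values here, the only measured step at that position is the one from ethyl to cyclopentyl, where a 55-fold higher number from compound 1 to compound 2 (1.74 log units; beyond the scatter); the step from compound 2 to compound 3 concerns a different position and bears little on the ring enlargement. Enlarging the ring further is therefore expected to move the number in the same direction as before, but by a smaller amount, since the larger part of the change has already been made. Compound 4 is accordingly expected to give 160 nM, with a range from 50 nM to 500 nM, which would mean a 1.8-fold higher number from compound 2 to compound 4 (0.26 log units; within the scatter).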

Compound 4, inhibition constant: 31.1 nM
Compound 4: the middle estimate sits 5.1-fold (0.71 log units) above what was measured; the whole stated range lies above it.
By their numbers in this assay, from the lowest: compound 1; then compound 4; then compounds 2 and 3 (each within the scatter of the next).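

In this assay, the response at the saturated chain carbon bound to an aromatic carbon and a carbonyl carbon does not simply follow ring size: the earlier step shows a 55-fold higher number from compound 1 to compound 2 (1.74 log units; beyond the scatter), yet the move to cyclohexyl reverses part of it, with a 2.9-fold lower number from compound 2 to compound 4 (0.46 log units; beyond the scatter). Cyclohexyl still falls well short of ethyl, with a 19-fold higher number from compound 1 to compound 4 (1.29 log units; beyond the scatter), so among these three groups the order is ethyl, then cyclohexyl, then cyclopentyl. Nothing available explains the difference between the five-membered and six-membered rings.

The compounds shown leave open where methyl, a longer chain such as butyl, or a cycloheptyl ring would fall at this position. They also leave open whether cyclohexyl would bring a similar change in compound 3, which carries cyclohexylsulfanyl instead of 4-methylpiperidin-1-yl.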